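This account rests on a few compounds, and the source may have more. Where it says the series, first, only, none or still open, it means among the compounds named here.

Measured so far in a functional assay on Hep2C cells (Homo sapiens) for antiproliferative activity, read by MTT assay, with a stated time of 24 h; on this read-out higher numbers stand for weaker inhibition and lower numbers for stronger inhibition:
- compound 1 `COc1ccc2nc(-c3ccccc3)cc(-c3ccccc3)c2c1`: 496000 nM
- compound 2 `Cc1ccc(-c2cc(-c3ccccc3)c3cc(Br)ccc3n2)cc1`: 175000 nM
- compound 3 `Oc1ccc2c(-c3ccccc3)cc(-c3ccccc3)nc2c1`: "not determined" (no result reported)

Compound 2 stands lowest of the two numbers; its nearest neighbour, compound 1, stands higher by a gap beyond the scatter. Compound 3 contributes no number and gives no direction.

The next compound, compound 4 `N#Cc1ccc(-c2cc(-c3ccccc3)c3cc(Br)ccc3n2)cc1`, differs from compound 2 in one place: cyano in place of methyl on an aromatic carbon. Among the compounds with values here, no step of this kind, cyano in place of methyl on an aromatic carbon, exists among the measured compounds, so nothing measured here points the way. The expectation is a step no larger than the scatter, in either direction, in this assay. Compound 4 is estimated at 150000 nM, with a range of 50000 nM to 450000 nM, which means an expected step of a 1.2-fold lower number from compound 2 to compound 4 (0.07 log units; within the scatter).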

Compound 4, half-maximal inhibitory concentration: 98800 nM
The estimate for compound 4 lay 1.5-fold (0.18 log units) above the measured number; the measured number falls inside the stated range.
By their numbers in this assay, from the lowest: compounds 4 and 2 (each within the scatter of the next); then compound 1.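

Cyano in place of methyl on the aromatic carbon para to a large group gives the first one-place comparison in the series: in this assay the change from 4-methylphenyl to 4-cyanophenyl gives a 1.8-fold lower number from compound 2 to compound 4 (0.25 log units; within the scatter), so the two groups cannot be told apart at this position. The added hydrogen-bond acceptor and triple bond thus come with no step beyond the scatter. No measurement shown bears on the origin of this small step.

From the compounds shown here alone, whether an amine or a carboxylic acid at this position would give a step beyond the scatter remains open. So does whether a longer chain in place of methyl would leave the number within the scatter of compound 2.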